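Methyl to trifluoromethyl at the limit of the assay

This account rests on a few compounds, and the source may have more. Where it says the series, first, only, none or still open, it means among the compounds named here.

In a functional assay on SK-MEL-28 cells (Homo sapiens) for inhibition (on this read-out lower numbers stand for stronger inhibition and higher numbers for weaker inhibition), compound 1 (`CC(=O)Oc1ccc(/C=C/c2ccc3ccccc3c2)cc1`) gives > 5000 nM, which is a limit of the assay and not a number. Compound 2 (`Oc1ccc(/C=C/c2ccc3ccccc3c2)cc1`) gives 4060 nM. Compound 3 (`Cc1ccc(/C=C/c2ccc3ccccc3c2)cc1`) gives > 5000 nM, again only a limit. Compound 3 therefore rests on (the limit of > 5000 nM in this assay, at which 2 of the 3 values shown sit).

Compound 4 (`FC(F)(F)c1ccc(/C=C/c2ccc3ccccc3c2)cc1`) carries trifluoromethyl in place of methyl on an aromatic carbon, para to a large group: trifluoromethyl in place of methyl on an aromatic carbon.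

Three measured swaps on that carbon bear on this change, though none involves trifluoromethyl. Hydroxy to methyl gave an at least 1.2-fold higher number from compound 2 to compound 3 (0.09 log units; that floor lies within the scatter). Loss of the acetyl gave an at least 1.2-fold lower number from compound 1 to compound 2 (0.09 log units; that floor lies within the scatter). Acetoxy to methyl gave a step that the two limits leave unreadable from compound 1 to compound 3. None of these shows a change beyond the scatter, so no step beyond the scatter is expected here either. The expected step is a step that the limit leaves unreadable from compound 3 to compound 4. For compound 4 the estimated value is 6000 nM, with an expected range from 3000 nM to 12000 nM.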

Compound 4, half-maximal inhibitory concentration: > 5000 nM
Compound 4: a limit, no number; the forecaster's own chance of this, stated with the estimate: 75%; the middle value does not contradict the limit.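

The value for compound 4 is again a limit of the assay, so trifluoromethyl, like methyl and acetoxy, gives this carbon no number of its own. Going by these compounds alone, the steps that join compound 4 to compound 3 and to compound 1 cannot be read, and the one comparison that can be read, with hydroxy, is an at least 1.2-fold higher number from compound 2 to compound 4 (0.09 log units; that floor lies within the scatter), which does not set trifluoromethyl apart from hydroxy. Most of this small set now rests on a single limit: the limit of > 5000 nM in this assay, at which 3 of the 4 values shown sit.

Within the data shown here, compound 2, at 4060 nM, remains the only compound here with an actual number, so it stays open whether any group on this carbon can give a step beyond the scatter. From the compounds shown here alone, an amine or a carboxylic acid in this place could answer that, while the true gaps among the compounds at the limit remain unknown.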